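This account rests on a few compounds, and the source may have more. Where it says the series, first, only, none or still open, it means among the compounds named here.

Compound 1, `CC1=C(C(=O)OC(C(F)(F)F)C(F)(F)F)C(c2ccoc2)NC(=O)N1`, gives 2% in an assay on HEK293 cells for displacement of a labelled ligand from adenosine receptor A2b (Homo sapiens), read by radioligand binding, with a stated time of 30 min, tested at 1 uM; a lower number here means less inhibition, a higher number more inhibition at the concentration tested (going by the name of the read-out).
Compound 2, `CC1=C(C(=O)OC(C)C(F)(F)F)C(c2ccoc2)NC(=O)N1`, gives 23%.
Compound 3, `CC(C)OC(=O)C1=C(C(F)(F)F)NC(=O)NC1c1ccoc1`, gives 37%.

Among these three numbers compound 1 stands lowest. Going by the values given here, the one measured step, a number 21 percentage points higher from compound 1 to compound 2 (beyond the scatter), lies beyond the scatter and concerns only the ester part of the shared core, where methyl replaces trifluoromethyl. Compound 3 stands furthest from compound 1, but the two differ in more than one place, so only their two values can be compared.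

Compound 4, `CC1=C(C(=O)OC(C(F)(F)F)C(F)(F)F)C(c2ccco2)NC(=O)N1`, differs from compound 1 in a different region: furan-2-yl in place of furan-3-yl on a saturated ring carbon. No measured step touches this ring, so nothing shown tells how moving the attachment point of the furan affects the read-out. With no guidance, the expected step from compound 1 is a number 4 percentage points higher from compound 1 to compound 4 (within the scatter), which is within the scatter. Compound 4 is therefore estimated at 6%, with a range from -10% to 25%.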

Compound 4, a percentage reported as inhibition, at one concentration (the size of the read-out at that concentration, not a potency): 1%
Compound 4: the middle estimate sits 5 percentage points above what was measured; the range from low to high includes it.
By their numbers in this assay, from the lowest: compounds 4 and 1 (each within the scatter of the next); then compound 2; then compound 3.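

Swapping furan-3-yl for furan-2-yl on the saturated ring carbon gives a number 1 percentage points lower from compound 1 to compound 4 (within the scatter) in this assay, the first measured change at this position, and it cannot be told apart from repeat-measurement noise. With compound 1 at 2% and compound 4 at 1%, both values lie so close to zero that this pair has little room to show any further loss, so it says little about how much the attachment point matters. No supporting measurement is available to explain this result.

As far as these compounds go, whether the same swap would change the number on the esters of compound 2 or compound 3, whose values are higher, remains open. So does what a phenyl ring, a thiophene ring or a longer chain would give at this position.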